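The source may report more compounds than this note shows. Statements on the series, on what has been measured and on what is new or still open speak of the compounds shown alone.

Compound 1 `Cc1nn(-c2ncnc3nc[nH]c23)c2c1C(OCc1ccccc1F)CC(=O)N2` is the better of the two measured compounds: in a functional assay on HEK293 cells for agonist activity at G-protein coupled receptor 39 (Homo sapiens), read by scintillation proximity assay and inositol phosphate accumulation, with a stated time of 75 min (a lower number here means that less compound is needed, a higher number that more compound is needed for the effect), compound 1 gives 78 nM, while compound 2 `Cc1cc(C)n(CCOC2CC(=O)Nc3c2c(C)nn3-c2ncnc3nc[nH]c23)n1` gives 2000 nM. Among the compounds with values here, the single measured step, a 26-fold higher number from compound 1 to compound 2 (1.41 log units; beyond the scatter), shows that changing the group beyond the oxygen already costs a great deal. Compound 3 `Cc1nn(-c2ncnc3nc[nH]c23)c2c1C(C(=O)N(C)c1ccccc1)CC(=O)N2` differs from compound 1 in another way: methyl(phenyl)carbamoyl in place of (2-fluorobenzyl)oxy on a saturated ring carbon. This removes the ether linkage itself and puts an amide-bearing group in its place, so the step from compound 1 to compound 2 bears on it only loosely, as a sign that this side of the shared core does not tolerate change easily. On that basis a weakening is expected, probably beyond the scatter but of uncertain size, and compound 3 is estimated at 450 nM with a range of 80 nM to 3000 nM, which would mean a step of a 5.8-fold higher number from compound 1 to compound 3 (0.76 log units; beyond the scatter).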

Compound 3, half-maximal effective concentration: 5220 nM
Estimate against measurement, compound 3: 12-fold (1.06 log units) below; the whole stated range lies below it.
By their numbers in this assay, from the lowest: compound 1; then compound 2; then compound 3.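

In this assay, methyl(phenyl)carbamoyl on this saturated ring carbon gives a 67-fold higher number from compound 1 to compound 3 (1.83 log units; beyond the scatter) and so does not keep the low number of compound 1, even though the entering group has one six-membered aromatic ring of carbon only, like the group it replaces, and nearly the same heavy-atom count. The change also gives a 2.6-fold higher number from compound 2 to compound 3 (0.42 log units; beyond the scatter) as a modest further rise, which shows that this position responds to loss of the ether linkage as well as to changes beyond the oxygen. Nothing at hand explains this loss.

The compounds shown leave open how an amine or a carboxylic acid on this ring carbon would compare. They also leave open whether a carbamoyl group carrying the amide hydrogen in place of the methyl would recover any of the lost ground.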